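Cytotoxicity notes: the step from compound 2 to compound 3

The source may hold more compounds than are shown below. What is called first, only, known or untested is meant among the compounds shown, and "the series" means these compounds.

In an ADME assay on HepG2 cells (Homo sapiens) for cytotoxicity, with a stated time of 72 h (on this read-out higher numbers stand for an effect only at larger amounts of compound and lower numbers for an effect already at smaller amounts), compound 1 (`Cc1cc(NC(=O)Nc2cccc(F)c2)c2ccccc2n1`) gives > 25000 nM as a limit of the assay and not a number.

Compound 2 (`Cc1cc(NC(=O)Nc2ccc(N)cc2)c2ccccc2n1`) gives > 25000 nM as a limit too, so its position is known only as a limit.

The change to compound 3 (`Cc1cc(NC(=O)Nc2cccc(Cl)c2)c2ccccc2n1`) is 3-chlorophenyl in place of 4-aminophenyl on an amide-type nitrogen with 3-chlorophenyl in place of 4-aminophenyl on an amide-type nitrogen.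

Within the data shown here, the only measured step is a step that the two limits leave unreadable from compound 1 to compound 2 and it carries no size over to this change. The remaining evidence is the limit of > 25000 nM in this assay, at which 2 of the 2 values shown sit, and it gives no direction either.

No step beyond the scatter is therefore expected in this assay for compound 3, though this expectation rests on limits alone and a real shift cannot be excluded.

For compound 3 the estimate is 28000 nM with an expected range of 12000 nM to 60000 nM on this read-out.

The estimated change is a step that the limit leaves unreadable from compound 2 to compound 3 and a report as a limit is the expected outcome.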

Compound 3, half-maximal effective concentration: 19000 nM
The estimate for compound 3 lay 1.5-fold (0.17 log units) above the measured number, and the stated range covers the measured number.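

Among these compounds, compound 3 is the first to give a number and not a limit in this assay, so a change on this amide-type nitrogen can bring the read-out within the measurable range. Placing 3-chlorophenyl for 4-aminophenyl gives an at least 1.3-fold lower number from compound 2 to compound 3 (0.11 log units; that floor lies within the scatter), and the smaller exchange of chloro for fluoro on an aromatic carbon gives an at least 1.3-fold lower number from compound 1 to compound 3 (0.11 log units; that floor lies within the scatter); both are floors, so neither shows a shift beyond the scatter, and the true size of each stays unknown. The two changes thus end at the same measured compound, and the picture remains one number set against two limits: the limit of > 25000 nM in this assay, at which 2 of the 3 values shown sit.

The compounds shown leave open how far the values of compound 1 and compound 2 lie from that of compound 3, and therefore whether either step is real or how the two compare in size. Also open, going by these compounds, is how a bromo or methoxy group on the phenyl ring, or a carboxylic acid or longer chain in place of the 3-chlorophenyl, would read in this assay.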